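This account rests on a few compounds, and the source may have more. Where it says the series, first, only, none or still open, it means among the compounds named here.

Working notes on the benzylhydrazone series. Compound 1, `COc1ccccc1/C=N/N(Cc1ccccc1)Cc1ccccc1`, is the reference point at the weak end: in an assay on liver (Sus scrofa) for inhibition of glucose-6-phosphatase catalytic subunit 1 (Homo sapiens), using microsomes (a lower number here means a stronger inhibitor, a higher number a weaker inhibitor), compound 1 gives only the assay limit of > 100000 nM, not a number. Going by the values given here, compound 2, `Oc1ccc(/C=N/N(Cc2ccccc2)Cc2ccccc2)cc1`, is the sole compound with a measured figure; in this assay compound 2 gives 2400 nM. Among the compounds with values here, the step of an at least 41-fold lower number from compound 1 to compound 2 (1.61 log units; beyond the scatter) is the one measured change on the aryl group attached to the carbon with a double bond to nitrogen, and it is large, though its true size is open because compound 1 sits at the limit of > 100000 nM in this assay, at which 1 of the 2 values shown sits.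

Compound 3, `Clc1ccc(/C=N/N(Cc2ccccc2)Cc2ccccc2)cc1Cl`, carries the change (3,4-dichlorophenyl in place of 4-hydroxyphenyl on a carbon with a double bond to nitrogen). Within the data shown here, the only measured step that bears on this position is an at least 41-fold lower number from compound 1 to compound 2 (1.61 log units; beyond the scatter); it went from a limit to a number, so it fixes direction rather than magnitude, and no measured compound carries a halogen on this ring. A weaker number than compound 2 is expected for compound 3, with the step of a 4.2-fold higher number from compound 2 to compound 3 (0.62 log units; beyond the scatter) taken as a modest loss. The estimate for compound 3 in this assay is 10000 nM, within 2000 nM to 60000 nM.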

Compound 3, half-maximal inhibitory concentration: 2000 nM
Estimate against measurement, compound 3: 5.0-fold (0.70 log units) above; the measured number falls inside the stated range.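

In this assay, the step of a 1.2-fold lower number from compound 2 to compound 3 (0.08 log units; within the scatter) leaves the 4-hydroxyphenyl and 3,4-dichlorophenyl groups indistinguishable on the carbon with a double bond to nitrogen. A figure in this range at this position therefore does not depend on the hydrogen-bond donor and acceptor counted on the 4-hydroxyphenyl group, since the 3,4-dichlorophenyl group has neither and the two groups share only the six-membered aromatic ring of carbon. The step of an at least 50-fold lower number from compound 1 to compound 3 (1.69 log units; beyond the scatter) adds a second group that reads clearly better than the 2-methoxyphenyl group, so the earlier gain is not particular to the 4-hydroxyphenyl group, though its true size stays open, since the figure for compound 1 is a limit and not a number: the limit of > 100000 nM in this assay, at which 1 of the 3 values shown sits.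

The compounds shown leave open how a carboxylic acid or an amine on this ring would read, and whether a single chlorine would match the 3,4-dichlorophenyl group. They also leave open whether anything on this ring can move the number clearly past the level shared by compound 2 and compound 3, and how far that level depends on the rest of the shared core.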